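Adding a 4-chlorophenyl group to compound 1

The source may hold more compounds than are shown below. What is called first, only, known or untested is meant among the compounds shown, and "the series" means these compounds.

- compound 1 `O=C1COc2ccc(-c3cccc(NS(=O)(=O)c4ccc(F)cc4)c3)cc2N1`: > 40000 nM (a limit, not a number)
- compound 2 `COc1ccc(N2C(=O)COc3ccc(-c4ccc(O)cc4)cc32)cc1`: 16400 nM

In a functional assay on HeLa cells (Homo sapiens) for antiproliferative activity, read by MTT assay, with a stated time of 72 h (a lower number here means a stronger inhibitor, a higher number a weaker inhibitor), compound 1 gives only a limit and no number, which places it at the limit of > 40000 nM in this assay, at which 1 of the 2 values shown sits. Compound 2 gives a true number, 16400 nM. Among the compounds with values here, no direct step links these two compounds, so their values can only be set side by side.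

The next compound, compound 3 `O=C1COc2ccc(-c3cccc(NS(=O)(=O)c4ccc(F)cc4)c3)cc2N1c1ccc(Cl)cc1`, is compound 1 with a single change: 4-chlorophenyl in place of hydrogen on an amide-type nitrogen in a ring. In short, 4-chlorophenyl stands in place of hydrogen on an amide-type nitrogen in a ring.

Within the data shown here, compound 2, at 16400 nM, also carries an aromatic ring on an amide-type nitrogen in a ring, and it is the only compound here with a number. On that slender basis, a modest move towards stronger inhibition is expected in this assay. The estimated step is an at least 3.0-fold lower number from compound 1 to compound 3 (0.48 log units; beyond the scatter). Compound 1 has no number, so the size of this step remains loose, and compound 3 could still return only a limit. For compound 3 the expected value is 13000 nM, with an estimated range from 4000 nM to 35000 nM.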

Compound 3, half-maximal inhibitory concentration: 35000 nM
Compound 3: middle estimate off by 2.7-fold (0.43 log units), on the low side, and the stated range covers the measured number.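

In this assay compound 1 gives > 40000 nM, which is a limit and not a number. With 4-chlorophenyl in place of hydrogen on the amide-type nitrogen in the ring, the core of compound 1 now yields a true number, and the change amounts to an at least 1.1-fold lower number from compound 1 to compound 3 (0.05 log units; that floor lies within the scatter). This shows that the position can carry an aromatic ring without the value going past the limit, but only the floor of the step is fixed, and its true size stays unknown because compound 1 rests on a limit: the limit of > 40000 nM in this assay, at which 1 of the 3 values shown sits.

As far as these compounds go, it remains open whether a small group such as methyl on the same nitrogen, or a phenyl ring with an amine in place of the chlorine, would give a lower number than compound 3 does. The compounds shown also cannot separate the part played by the chlorine from that of the ring carrying it, and compound 2 differs from compound 3 in more than one place, so it offers no direct comparison.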